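Sulfur in Place of Oxygen on a Cyclopropyl Carbamate

The compounds below may be only part of what the source reports. "The series", "measured", "known", "first", "only" and "open" are said of these compounds alone.

Compound 2 `O=C(NC1CC1)OC[C@H]1OC(n2cnc3c(NC4CCOC4)ncnc32)[C@H](O)[C@@H]1O` gives 209 nM in an assay on DDT1 cells (Cricetulus griseus) for binding affinity to adenosine receptor A1 (Homo sapiens), read by radioligand binding (a higher number here means a weaker inhibitor, a lower number a stronger inhibitor), the higher of the two numbers shown, while compound 1 `CCNC(=O)OC[C@H]1OC(n2cnc3c(NC4CCOC4)ncnc32)[C@H](O)[C@@H]1O` gives 167 nM; the step of a 1.3-fold higher number from compound 1 to compound 2 (0.10 log units; within the scatter) stays within the scatter. Compound 3 `O[C@@H]1[C@@H](CO/C(S)=N/C2CC2)OC(n2cnc3c(NC4CCOC4)ncnc32)[C@@H]1O` differs from compound 2 by a group of 6 heavy atoms (4 carbon, 1 nitrogen, 1 sulfur; one three-membered non-aromatic ring of carbon only) in place of a group of 6 heavy atoms (4 carbon, 1 nitrogen, 1 oxygen; one three-membered non-aromatic ring of carbon only), on an oxygen on a saturated carbon, on an oxygen on a saturated carbon whose other neighbours are a saturated chain carbon. Going by the values given here, the single measured step swapped cyclopropyl for ethyl and leaves this part untouched, so no measured step bears on the change; the expected step of a 1.2-fold higher number from compound 2 to compound 3 (0.08 log units; within the scatter) is none beyond the scatter. Compound 3 is estimated at 250 nM, with a range from 90 nM to 700 nM.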

Compound 3, inhibition constant: 157 nM
Estimate against measurement, compound 3: 1.6-fold (0.20 log units) above; low and high end bracket the measured number.
By their numbers in this assay, from the lowest: compounds 3, 1 and 2 (each within the scatter of the next).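

At this position, on an oxygen on a saturated carbon, sulfur in place of oxygen stays within the scatter in this assay, giving a 1.3-fold lower number from compound 2 to compound 3 (0.12 log units; within the scatter). Set against the ethyl carbamate, which differs in both the chain and this atom, the result is also within the scatter, at a 1.1-fold lower number from compound 1 to compound 3 (0.03 log units; within the scatter). No other measurement helps to interpret this result.

The compounds shown cover only ethyl and cyclopropyl on the nitrogen. Going by these compounds, whether a longer chain such as butyl there, or an amine in place of the sulfur, would give a step beyond the scatter remains open.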